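The source may hold more compounds than are shown below. What is called first, only, known or untested is meant among the compounds shown, and "the series" means these compounds.

In a functional assay on HEK293 cells for agonist activity at Toll-like receptor 8 (Homo sapiens), read by reporter gene assay (a lower number here means that less compound is needed, a higher number that more compound is needed for the effect), compound 2 `CCCC(C)Nc1oc2c(C)ncc(CO)c2c1Nc1ccccn1` gives 9010 nM. This is the lowest of the two numbers available, yet compound 3 `Cc1ncc(CO)c2c(Nc3cnccn3)c(NCc3ccccc3)oc12` gives 9790 nM in this assay, and the two values lie within the usual scatter, so neither can be placed above the other. Compound 1 `Cc1ncc(CO)c(-c2nc3ccccn3c2NC2CCCCC2)c1OCc1ccccc1` is reported in this assay as "not active" (no number reported).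

Compound 4 `Cc1ncc(CO)c2c(Nc3ccccn3)c(N[C@@H](C)c3ccccc3)oc12` keeps the core of compound 2 and changes one group: 1-phenylethyl in place of 1-methylbutyl on a nitrogen on an aromatic ring. Within the data shown here, no measured pair shows what this kind of change does in this assay, so the size of the step has to be guessed. Compound 4 is expected to give an estimated 5000 nM, with a range from 1500 nM to 20000 nM, so that the estimated step of a 1.8-fold lower number from compound 2 to compound 4 (0.26 log units; within the scatter) stays within the scatter.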

Compound 4, half-maximal effective concentration: 4270 nM
The estimate for compound 4 lay 1.2-fold (0.07 log units) above the measured number; low and high end bracket the measured number.
By their numbers in this assay, from the lowest: compound 4; then compounds 2 and 3 (each within the scatter of the next).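

In this assay, among these compounds, the swap of 1-methylbutyl for 1-phenylethyl on a nitrogen on an aromatic ring brings a 2.1-fold lower number from compound 2 to compound 4 (0.32 log units; beyond the scatter) and gives the first measured step at this position. The nitrogen therefore takes a group with a six-membered aromatic ring of carbon only without the number rising, though the step is modest. Nothing at hand gives a reason for this step. Still open, on these data alone, is whether the mirror-image form of 1-phenylethyl gives a similar number. The compounds shown also leave open how a 1-phenylpropyl or 1-cyclopropylethyl group would behave on this nitrogen.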